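A few compounds are considered here, and "the series" means these few. Any claim that something is new, unique, unknown or untested is made for them only; others in the source may bear on it.

Working notes on the series built around the shared core of compound 1 `CC(C)[C@H](NC(=O)COc1cccc2ccccc12)C(=O)N[C@@H](CC(=O)O)C(=O)COc1ccccc1C(F)(F)F`. In a functional assay on Jurkat cells (Homo sapiens) (on this read-out lower numbers stand for stronger inhibition and higher numbers for weaker inhibition), compound 1 gives only a limit, > 100000 nM. Compound 2 `CC(C)[C@H](NC(=O)COc1cccc2ccccc12)C(=O)N[C@@H](CC(=O)O)C(=O)COc1cccc(C(F)(F)F)c1` also returns a limit in this assay, > 100000 nM. Compound 3 `CC(C)[C@H](NC(=O)COc1cccc2ccccc12)C(=O)N[C@@H](CC(=O)O)C(=O)COc1cc(C(F)(F)F)cc(C(F)(F)F)c1` likewise gives a limit in this assay, > 100000 nM. Among the compounds with values here, compound 2 thus stands where every value so far stands, at the limit of > 100000 nM in this assay, at which 3 of the 3 values shown sit, with no number that could be ranked against the others.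

The step from compound 1 to compound 2 is a step that the two limits leave unreadable from compound 1 to compound 2, and the step from compound 2 to compound 3 is a step that the two limits leave unreadable from compound 2 to compound 3. Within the data shown here, neither has a readable size, so the run of three offers no measured step that can be carried over to the next change.

Compound 4 `CC(C)[C@H](NC(=O)COc1cccc2ccccc12)C(=O)N[C@@H](CC(=O)O)C(=O)COc1ccc([N+](=O)[O-])cc1` differs from compound 2 by 4-nitrophenyl in place of 3-(trifluoromethyl)phenyl on an oxygen on a saturated carbon. Among the measured compounds shown here, no measured step bears on this change; the only guide is that the three variants tried so far all sit at the limit, as the limit of > 100000 nM in this assay, at which 3 of the 3 values shown sit, records. The expectation is therefore no step beyond the scatter, with the change from compound 2 to compound 4 estimated at a number no higher from compound 2 to compound 4 (the limit leaves the size open). For compound 4 in this assay the estimate is 100000 nM, within 20000 nM to 500000 nM, and the expected outcome is that a limit rather than a number is reported once more.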

Compound 4, half-maximal inhibitory concentration: > 100000 nM
Compound 4 was reported as a limit; the forecaster's own chance of this, stated with the estimate: 85%; the middle value lies on the limit itself.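

In this assay compound 4 gives > 100000 nM, which is a limit and not a number. Within the data shown here, its steps from compound 1 and compound 2 therefore cannot be read, and no new step comes from this result. The compounds shown leave open which change on the shared core, if any, would yield a measurable number: the limit of > 100000 nM in this assay, at which 4 of the 4 values shown sit.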